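Methoxy in Place of Hydrogen on the Ring of Compound 2

The source may hold more compounds than are shown below. What is called first, only, known or untested is meant among the compounds shown, and "the series" means these compounds.

Compound 2 `COc1ccc(C(=O)/C=C/c2cc(-c3cc(OC)c(OC)c(OC)c3)n[nH]2)cc1OC` was tested in a functional assay on MDA-MB-435 cells (Homo sapiens) for cytotoxicity, read by sulforhodamine B assay, with a stated time of 48 h, tested at 0.1 uM (a higher number here means a weaker effect of the compound at the concentration tested, a lower number a stronger effect), and gives 92%. On the numbers shown it stands second highest of three, though its steps to both other compounds lie within the scatter: compound 3 `COc1cc(-c2cc(/C=C/C(=O)c3ccc(F)c(F)c3)[nH]n2)cc(OC)c1OC` gives 90%, and compound 1 `COc1cc(-c2cc(/C=C/C(=O)c3ccc(Cl)c(Cl)c3)[nH]n2)cc(OC)c1OC` gives 96%. The measured steps are a number 4 percentage points lower from compound 1 to compound 2 (within the scatter), a number 6 percentage points lower from compound 1 to compound 3 (within the scatter) and a number 2 percentage points lower from compound 2 to compound 3 (within the scatter). Each of them exchanged one aryl group for another on a carbonyl carbon, and none moved the read-out beyond the scatter.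

Compound 4 `COc1cc(C(=O)/C=C/c2cc(-c3cc(OC)c(OC)c(OC)c3)n[nH]2)cc(OC)c1OC` differs from compound 2 in one place: methoxy in place of hydrogen on an aromatic carbon. Going by the values given here, no measured step puts a methoxy in place of hydrogen, so this change has no direct precedent among the three compounds. The nearest guide is that the exchanges on that carbonyl carbon all stayed within the scatter, which gives no reason to expect a step beyond the scatter for compound 4 in this assay. Compound 4 is therefore expected to give 90%, within 78% to 100%. This amounts to an expected step of a number 2 percentage points lower from compound 2 to compound 4 (within the scatter).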

Compound 4, a percentage reported as activity, at one concentration (the size of the read-out at that concentration, not a potency): 94%
Estimate against measurement, compound 4: 4 percentage points below, within the range that was stated.
By their numbers in this assay, from the lowest: compounds 3, 2, 4 and 1 (each within the scatter of the next).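

Methoxy in place of hydrogen, on an aromatic carbon ortho to a methoxy group and meta to a large group, gave a number 2 percentage points higher from compound 2 to compound 4 (within the scatter) in this assay. Where the earlier steps exchanged one whole aryl group for another, this one adds a single group to the aryl ring of compound 2, and at this position the read-out still stayed within the scatter. No evidence is available on what lies behind this result.

The compounds shown carry only hydrogen or methoxy at this carbon, so they leave open what an amine, a carboxylic acid or a longer chain would do there. They also leave open whether any of these compounds would separate from the others at another concentration, since only one concentration is shown.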